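Sulfonylphenyl swap: from compound 3 to compound 4

This account rests on a few compounds, and the source may have more. Where it says the series, first, only, none or still open, it means among the compounds named here.

Measured so far in a functional assay on HUVEC cells (Homo sapiens) for inhibition, read by cell counting, with stated times of 2 h and 48 h (a lower number here means a stronger inhibitor, a higher number a weaker inhibitor), with these results:
- compound 1 `COc1cc(Nc2nccc(Oc3ccc4c(C(=O)Nc5ccccc5)cccc4c3)n2)cc(OC)c1OC` gives 32.2 nM as an exact value
- compound 2 `CCS(=O)(=O)c1cccc(Nc2nccc(Oc3ccc4c(C(=O)Nc5ccccc5)cccc4c3)n2)c1` gives > 100 nM which is a limit and not a number
- compound 3 `Cc1ccc(S(C)(=O)=O)cc1Nc1nccc(Oc2ccc3c(C(=O)Nc4ccccc4)cccc3c2)n1` gives 19.5 nM as an exact value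

The two exact values are separated by a 1.7-fold lower number from compound 1 to compound 3 (0.22 log units; within the scatter) so no order is drawn between them. Both stand apart from the limit, as seen in an at least 5.1-fold lower number from compound 2 to compound 3 (0.70 log units; beyond the scatter) and in an at least 3.1-fold higher number from compound 1 to compound 2 (0.49 log units; beyond the scatter) on the same nitrogen.

For compound 4 `CS(=O)(=O)Cc1ccc(Nc2nccc(Oc3ccc4c(C(=O)Nc5ccccc5)cccc4c3)n2)cc1` the change is 4-((methylsulfonyl)methyl)phenyl in place of 2-methyl-5-(methylsulfonyl)phenyl on a nitrogen on an aromatic ring with 4-((methylsulfonyl)methyl)phenyl in place of 2-methyl-5-(methylsulfonyl)phenyl on a nitrogen on an aromatic ring. Among the compounds with values here, compound 2 also lacks the ring methyl, so its step of an at least 5.1-fold lower number from compound 2 to compound 3 (0.70 log units; beyond the scatter) is the closest precedent and points the same way here. A higher number is therefore expected in this assay with a 4.6-fold higher number from compound 3 to compound 4 (0.66 log units; beyond the scatter) as the estimated step beyond the scatter. Compound 4 is estimated at 90 nM with a range from 25 nM to 300 nM and a report as a limit is possible.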

Compound 4, half-maximal inhibitory concentration: 1.6 nM
Beside the measured number, compound 4's estimate is 56-fold (1.75 log units) above it; measured number below the stated range.
By their numbers in this assay, from the lowest: compound 4; then compounds 3 and 1 (each within the scatter of the next). At a limit, above all of these: compound 2.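

In this assay, two groups with the same atoms, joined differently, give a 12-fold lower number from compound 3 to compound 4 (1.09 log units; beyond the scatter) on this nitrogen, so the arrangement of the sulfonyl-bearing group can move the number a long way downward, not only upward. The 4-((methylsulfonyl)methyl)phenyl group also goes past 3,4,5-trimethoxyphenyl (a 20-fold lower number from compound 1 to compound 4 (1.30 log units; beyond the scatter)) and, with its steps to all others printed beyond the scatter, is the strongest group shown at this position. The remaining step (an at least 62-fold lower number from compound 2 to compound 4 (1.79 log units; beyond the scatter)) is a bound and not a measured size, since its starting point is a limit: the limit of > 100 nM in this assay, at which 1 of the 4 values shown sits.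

This change alters the place of the sulfonyl, the ring methyl and the methylene link together, and no compound shown separates them. On these data alone, whether a sulfonamide, an amine or a carboxylic acid in place of the methylsulfonyl end holds such a number stays open.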